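The compounds below may be only part of what the source reports. "The series", "measured", "known", "first", "only" and "open" are said of these compounds alone.

Of the compounds shown here, two of this set have been tested in a functional assay on HCC1806 cells (Homo sapiens) for inhibition, read by sulforhodamine B assay, tested at 10 uM; a higher number here means more inhibition at the concentration tested (going by the name of the read-out), a lower number less inhibition. Compound 1 `CC(=O)N1N=C(c2ccc(-n3cncn3)cc2)CC1c1ccc(N(C)C)cc1` gives 11%. Compound 2 `CN(C)c1ccc(C2CC(c3ccc(-n4cncn4)cc3)=NN2C(=O)c2ccc(F)cc2)cc1` gives 15.6%; the two numbers lie within the scatter of each other, so neither can be placed above the other. Going by the values given here, the one measured step, a number 4.6 percentage points higher from compound 1 to compound 2 (within the scatter), swapped a group on the same carbonyl carbon as the change now considered and did not move the read-out beyond the scatter. Compound 3 `CN(C)c1ccc(C2CC(c3ccc(-n4cncn4)cc3)=NN2C(=O)/C=C/c2ccccc2)cc1` differs from compound 2 only in that (2-phenylethenyl in place of 4-fluorophenyl on a carbonyl carbon). Since that earlier step on the same carbonyl carbon stayed within the scatter, a similar small step, or none beyond the scatter, is expected in this assay, with no clear direction. The expected value for compound 3 is therefore 16%, within a range of 4% to 32%, meaning an expected step of a number 0.4 percentage points higher from compound 2 to compound 3 (within the scatter).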

Compound 3, a percentage reported as inhibition, at one concentration (the size of the read-out at that concentration, not a potency): -3.7%
Compound 3: the middle estimate sits 19.7 percentage points above what was measured; the measured number lies below the stated range.
By their numbers in this assay, from the lowest: compound 3; then compounds 1 and 2 (each within the scatter of the next).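

In this assay, going by these compounds alone, this carbonyl carbon proves sensitive to what it carries: replacing 4-fluorophenyl with 2-phenylethenyl gives a number 19.3 percentage points lower from compound 2 to compound 3 (beyond the scatter), the first step at this place to pass the scatter, whereas the earlier swap of methyl for 4-fluorophenyl did not. Measured against the methyl group, the same 2-phenylethenyl group gives a number 14.7 percentage points lower from compound 1 to compound 3 (beyond the scatter), so the lower number holds against both earlier groups. Nothing available explains why this group reads lower. The compounds shown leave open whether the double bond itself matters, which a saturated 2-phenylethyl group on the same carbonyl carbon would help to test. They also leave open whether any group at this place, such as an amine-bearing chain or a carboxylic acid, could raise the inhibition clearly above that of compound 1 and compound 2.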